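The compounds below may be only part of what the source reports. "The series", "measured", "known", "first", "only" and "open" are said of these compounds alone.

Compound 1 `COC(=O)[C@@]1(C)CCC=C2[C@@H]1CC[C@@H](C)[C@]2(C)Cc1c[nH]c2c(C)cccc12` and compound 2 `COC(=O)[C@@]1(C)CCC=C2[C@@H]1CC[C@@H](C)[C@]2(C)Cc1c(C)[nH]c2ccccc12` share one core and differ only in where a single methyl sits on the aromatic part. In a functional assay on WiDr cells (Homo sapiens) for inhibition, read by sulforhodamine B assay, with a stated time of 48 h (on this read-out lower numbers stand for stronger inhibition of growth and higher numbers for weaker inhibition of growth), compound 1 gives 26000 nM, and compound 2 gives 19000 nM; the two numbers lie within the scatter of each other, so compound 2 does not stand apart from compound 1 on what has been measured. Compound 3 `COC(=O)[C@@]1(C)CCC=C2[C@@H]1CC[C@@H](C)[C@]2(C)Cc1c(C)[nH]c2c(C)cccc12` carries both methyls: methyl in place of hydrogen on an aromatic carbon. For the measured compounds named here, no measured step informs this change, so in this assay no movement beyond the scatter is expected. Compound 3 is expected to give 15000 nM (range 6000 nM to 40000 nM). That estimate means a step of a 1.3-fold lower number from compound 2 to compound 3 (0.10 log units; within the scatter).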

Compound 3, concentration for 50% growth inhibition: 21000 nM
Compound 3: middle estimate off by 1.4-fold (0.15 log units), on the low side; low and high end bracket the measured number.
By their numbers in this assay, from the lowest: compounds 2, 3 and 1 (each within the scatter of the next).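

In this assay methyl in place of hydrogen on an aromatic carbon of the six-membered aromatic ring gives a 1.1-fold higher number from compound 2 to compound 3 (0.04 log units; within the scatter) and the same exchange on the other aromatic carbon gives a 1.2-fold lower number from compound 1 to compound 3 (0.09 log units; within the scatter) so carrying both methyls does not set compound 3 apart from either single-methyl compound. No further data bear on this result.
Open, on these data alone, is whether a group other than methyl on these aromatic carbons, such as an amine, a carboxylic acid or a longer chain, would give a step beyond the scatter, and whether an amide in place of the methyl ester on the shared core would move the number.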